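Fluoro on the pendant ring of two related cores

This account rests on a few compounds, and the source may have more. Where it says the series, first, only, none or still open, it means among the compounds named here.

Measured so far:
Compound 1 `NC1CCC(Nc2nc(NCc3ccc(-c4ccccc4)cc3)c3ncn(C4CCCC4)c3n2)CC1` gives 583 nM in a functional assay on MCF7 cells (Homo sapiens) for inhibition, with a stated time of 72 h; on this read-out lower numbers stand for stronger inhibition and higher numbers for weaker inhibition.
Compound 2 `NC1CCC(Nc2nc(NCc3ccc(-c4cccc(F)c4)cc3)c3ncn(C4CCCC4)c3n2)CC1` gives 293 nM in this assay.
Compound 3 `NC1CCC(Nc2nc(NCc3ccc(-c4ccccc4)nc3)c3ncn(C4CCCC4)c3n2)CC1` gives 483 nM in this assay.

Compound 4 `NC1CCC(Nc2nc(NCc3ccc(-c4cccc(F)c4)nc3)c3ncn(C4CCCC4)c3n2)CC1` has not yet been measured. It differs from compound 3 by fluoro in place of hydrogen on an aromatic carbon. The same change has already been made once: compound 2 differs from compound 1 by fluoro in place of hydrogen on an aromatic carbon, and that step read a 2.0-fold lower number from compound 1 to compound 2 (0.30 log units; within the scatter). Compound 3 and compound 1 differ in their cores by 6-phenylpyridin-3-yl in place of 4-phenylphenyl on a saturated chain carbon bound to a nitrogen on an aromatic ring; that step read a 1.2-fold lower number from compound 1 to compound 3 (0.08 log units; within the scatter). The two places carrying the fluoro are described in the same words, so the change from compound 3 to compound 4 is the same change as that from compound 1 to compound 2.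

For the measured compounds named here, on that single earlier step, the account expects compound 4 to move by a 1.7-fold lower number from compound 3 to compound 4 (0.24 log units; within the scatter) in this assay, a step of about the size seen because a 2.0-fold lower number from compound 1 to compound 2 (0.30 log units; within the scatter) was the only guide. Compound 4 is therefore estimated at 280 nM, with a range from 140 nM to 560 nM.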

Compound 4, half-maximal inhibitory concentration: 33 nM
Compound 4: middle estimate off by 8.5-fold (0.93 log units), on the high side, outside the stated range (below it).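

In this assay, fluoro in place of hydrogen on the pendant phenyl ring gave a 15-fold lower number from compound 3 to compound 4 (1.17 log units; beyond the scatter), so the size of this step depends on the core that carries it, and the step on the core of compound 1 does not predict the step on the core of compound 3: the same change on two cores in this assay, a 2.0-fold lower number (0.30 log units; within the scatter) from compound 1 to compound 2 and a 15-fold lower number (1.17 log units; beyond the scatter) from compound 3 to compound 4, 7.4-fold (0.87 log units) apart, beyond the scatter of two such steps The earlier step lies within the scatter, so that core gives no clear sign of a gain from this change, whereas on the core of compound 3 the gain is large. With a single pair on each core, this shows that the change cannot be carried over at a fixed size between these two cores, but it does not show why the cores differ or whether the same holds for any other core in the series.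

From the compounds shown here alone, whether chloro, methyl or a nitrile in place of the same hydrogen would also give a large step on the core of compound 3 remains open. Going by these compounds, it is equally open whether the large step from 3-fluorophenyl holds in other cell lines.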